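Swapping a Halogenated Phenyl Ring in a Histamine Antagonist Series

The compounds below may be only part of what the source reports. "The series", "measured", "known", "first", "only" and "open" are said of these compounds alone.

Of the compounds shown here, three sharing one core have been measured in a functional assay on ileum for antagonist activity at histamine H1 receptor (Cavia porcellus); on this read-out lower numbers stand for tighter binding and higher numbers for weaker binding. Compound 1 `N=C(NCCCc1c[nH]cn1)NCCSC(c1ccccc1)c1ccccn1` gives 100 nM in this assay. Compound 2 `N=C(NCCCc1c[nH]cn1)NCCCC(c1ccccc1)c1ccccn1` gives 251 nM in this assay. Compound 3 `N=C(NCCCc1c[nH]cn1)NCCC(c1ccc(Cl)cc1)c1ccccn1` gives 77.6 nM in this assay, the lowest of the three numbers; its gap to compound 1 lies within the scatter, so the two cannot be ranked, while compound 2 sits beyond the scatter with a higher number.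

Compound 4 `N=C(NCCCc1c[nH]cn1)NCCC(c1cccc(F)c1)c1ccccn1` has not yet been measured. It differs from compound 3 in one place: 3-fluorophenyl in place of 4-chlorophenyl on a saturated chain carbon bound to an aromatic carbon and a saturated chain carbon. Going by the values given here, no measured pair shows exactly this swap, so the size of the step is uncertain. Compound 2, which carries a plain phenyl ring, gives 251 nM in this assay, and on that slim basis a modest move toward higher numbers is expected, a 1.9-fold higher number from compound 3 to compound 4 (0.29 log units; within the scatter), although a step within the scatter would not be surprising. The estimate for compound 4 in this assay is 150 nM, with a range from 50 nM to 450 nM.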

Compound 4, dissociation constant: 158 nM
Compound 4: middle estimate off by 1.1-fold (0.02 log units), on the low side, and the stated range covers the measured number.
By their numbers in this assay, from the lowest: compounds 3, 1, 4 and 2 (each within the scatter of the next, the first and the last beyond it).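

Changing this ring substitution has a small but readable effect: in this assay, replacing 4-chlorophenyl with 3-fluorophenyl on the saturated chain carbon gives a 2.0-fold higher number from compound 3 to compound 4 (0.31 log units; beyond the scatter). The two groups match in heavy atoms, ring type, hydrogen-bond donors and acceptors and net charge, so the step comes from a swap that changes both the halogen and its ring position while leaving those counts untouched. Nothing available here explains why the number rises.

Because both features change in a single step, this pair cannot show which one matters, or whether both do. A 3-chlorophenyl or 4-fluorophenyl group at the same carbon would separate the two, while a 4-methoxyphenyl group would test a substituent that is not a halogen.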